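Dog liver stability after swapping fluoro for trifluoromethoxy

This account rests on a few compounds, and the source may have more. Where it says the series, first, only, none or still open, it means among the compounds named here.

- compound 1 `FC(F)(F)c1ccccc1-c1ccc2[nH]c(C3=NOC4(CCCCC4)C3)nc2c1`: 71%
- compound 2 `Fc1ccccc1-c1ccc2[nH]c(C3=NOC4(CCCCC4)C3)nc2c1`: 47%

For the measured compounds named here, in an ADME assay on microsomes from liver (Canis lupus familiaris) for metabolic stability, with a stated time of 10 min (on this read-out lower numbers stand for a less stable compound and higher numbers for a more stable compound), compound 2 gives 47%, the lower of the two numbers so far, while compound 1 stands at 71%. The next structure to be tested is compound 3 `FC(F)(F)Oc1ccccc1-c1ccc2[nH]c(C3=NOC4(CCCCC4)C3)nc2c1`, which keeps the shared core of compound 2 and changes a single group: trifluoromethoxy in place of fluoro on an aromatic carbon. In words, trifluoromethoxy takes the place of fluoro on an aromatic carbon, ortho to a large group.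

Going by the values given here, one measured step bears on this change: a number 24 percentage points lower from compound 1 to compound 2 (beyond the scatter), with fluoro in place of trifluoromethyl on an aromatic carbon. Compound 3 goes the opposite way, since fluoro leaves and a group with three fluorines enters. However, trifluoromethoxy is not trifluoromethyl, and no measured compound carries it, so this single step is only a loose guide. A rise of similar size is therefore expected, and the estimated step is a number 20 percentage points higher from compound 2 to compound 3 (beyond the scatter). For compound 3 the estimated value is 67%, with an expected range from 50% to 84%.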

Compound 3, percent of the compound remaining: 81%
Beside the measured number, compound 3's estimate is 14 percentage points below it; the range from low to high includes it.
By their numbers in this assay, from the lowest: compound 2; then compounds 1 and 3 (each within the scatter of the next).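

At this position, ortho to a large group, the new result makes fluoro the one that stands apart: in this assay the swap to trifluoromethoxy gives a number 34 percentage points higher from compound 2 to compound 3 (beyond the scatter), and this step is large. Compound 1 and compound 3 both carry a group with three fluorines, and the comparison gives a number 10 percentage points higher from compound 1 to compound 3 (within the scatter), so this read-out cannot tell trifluoromethoxy and trifluoromethyl apart, even though only trifluoromethoxy contains an oxygen. No measurement shown here accounts for this pattern among the three compounds.

As far as these compounds go, these compounds carry only fluoro, trifluoromethyl and trifluoromethoxy at this position, so it remains open whether a group without fluorine, such as methyl, methoxy or an amine, would fall with compound 2 or with compound 1 and compound 3. From the compounds shown here alone, it also remains open whether a plain hydrogen here would match any of them, and whether the gap between fluoro and the two groups with three fluorines would persist if another part of the shared core were changed.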